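Methoxy for difluoromethyl on a fused two-ring core

The source may hold more compounds than are shown below. What is called first, only, known or untested is meant among the compounds shown, and "the series" means these compounds.

Of the compounds shown here, two sharing a fused two-ring core have been tested in an ADME assay on brain (Rattus norvegicus) for protein binding; on this read-out higher numbers stand for a larger free fraction and lower numbers for a smaller free fraction. Within the data shown here, compound 1 `Cc1c(C(F)F)nnc2sc(C(=O)NC3CN(c4ncc(C(F)(F)F)cn4)C3)c(N)c12` gives 0.062 in this assay, the higher of the two numbers known so far. Compound 2 `COc1cc(N2CC(NC(=O)c3sc4nnc(Cl)c(C)c4c3N)C2)c(Cl)cn1` gives 0.01 in this assay, a gap beyond the usual scatter; the two compounds differ in several places, so no single change explains it.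

Compound 3 `COc1nnc2sc(C(=O)NC3CN(c4ncc(C(F)(F)F)cn4)C3)c(N)c2c1C` has not yet been measured. It differs from compound 1 by methoxy in place of difluoromethyl on an aromatic carbon. Only the two measured compounds and this change can guide an expectation here. A swap of two small groups on the core is expected to move the unbound fraction little, if at all beyond the scatter, so the step of a 1.3-fold higher number from compound 1 to compound 3 (0.11 log units; within the scatter) is estimated to be small and upward. Compound 3 is therefore expected to give about 0.08 in this assay, within a range from 0.04 to 0.16.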

Compound 3, unbound fraction: 0.039
Estimate against measurement, compound 3: 2.1-fold (0.31 log units) above; measured number outside the range, below it.
By their numbers in this assay, from the lowest: compound 2; then compounds 3 and 1 (each within the scatter of the next).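

Exchanging difluoromethyl for methoxy on the aromatic carbon next to the ring nitrogen gives a 1.6-fold lower number from compound 1 to compound 3 (0.20 log units; within the scatter) in this assay. Among these compounds, this is the first comparison here in which only one place differs, and it shows that this exchange does not move the read-out beyond the scatter, even though methoxy brings a hydrogen-bond acceptor that difluoromethyl lacks. No data shown here bear on what lies behind this step.

A single pair cannot show whether this position accepts other groups equally well: an amine or a longer chain such as ethoxy on the same carbon might give a quite different free fraction. From the compounds shown here alone, it also remains open whether the same exchange would give a similarly small step with a different group on the far end of the amide.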